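Cytotoxicity notes on a benzyloxy lipid amine series

A few compounds are considered here, and "the series" means these few. Any claim that something is new, unique, unknown or untested is made for them only; others in the source may bear on it.

Measured so far in an ADME assay on cells (Splenocyte, Mus musculus, strain BALB/c) for cytotoxicity, read by MTT assay, tested at 10 ug/mL; on this read-out higher numbers stand for a stronger effect at the one concentration tested and lower numbers for a weaker effect:
compound 1 `CCCCCCCCCCCCCCC(COCc1ccccc1)NC(=O)CCCC(=O)O` gives 6.4%
compound 2 `CCCCCCCCCCCCCCC(COCc1ccccc1)N(CC)CC` gives 15.6%
compound 3 `CCCCCCCCCCCCCCC(CN(CC)CC)NC(=O)OC(C)(C)C` gives 7.8%

The change from compound 2 to compound 1 is ((3-carboxypropyl)carbonyl)amino in place of diethylamino on a saturated chain carbon bound to two saturated chain carbons and produced a number 9.2 percentage points lower from compound 2 to compound 1 (within the scatter). Compound 4 `CCCCCCCCCCCCCCC(CNC(=O)CCCC(=O)O)NC(=O)OC(C)(C)C` is not yet measured; it arises from compound 3 by ((3-carboxypropyl)carbonyl)amino in place of diethylamino on a saturated chain carbon, two bonds along the chain from an amide-type nitrogen. This is the same kind of change as that from compound 2 to compound 1, but the place is not identical: in compound 2 the carbon is bound to two saturated chain carbons, in compound 3 it lies two bonds along the chain from an amide-type nitrogen. The difference between the cores of compound 3 and compound 2 is not broken down here. For compound 4 a step of a number 2.8 percentage points lower from compound 3 to compound 4 (within the scatter) is expected in this assay, smaller than a number 9.2 percentage points lower from compound 2 to compound 1 (within the scatter) because compound 3 starts from 7.8%. Compound 4 is estimated at 5%, expected between 0% and 15%.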

Compound 4, a percentage reported as activity, at one concentration (the size of the read-out at that concentration, not a potency): 1.2%
Estimate against measurement, compound 4: 3.8 percentage points above; the measured number falls inside the stated range.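

In this assay the exchange of diethylamino for ((3-carboxypropyl)carbonyl)amino gives a number 6.6 percentage points lower from compound 3 to compound 4 (within the scatter). Set beside the earlier step, the change carries from one core to the other with no size difference that can be told apart: the same change on two cores in this assay, a number 9.2 percentage points lower (within the scatter) from compound 2 to compound 1 and a number 6.6 percentage points lower (within the scatter) from compound 3 to compound 4, 2.6 percentage points apart, within the scatter of two such steps Neither step lies beyond the scatter, so the pair shows agreement between two small steps, not that the change has a real effect on either core, and two cores set no rule for the series.

Still open, on these data alone, is how a primary amine or a bare carboxylic acid in the place of diethylamino would read. Also open, as far as these compounds go, is whether the same agreement holds on a core with a shorter chain.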